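Side-chain change on the amide nitrogen: outlook for compound 4

A few compounds are considered here, and "the series" means these few. Any claim that something is new, unique, unknown or untested is made for them only; others in the source may bear on it.

Measured so far:
compound 1 `O=C(NC1CCCCC1)c1nc[nH]c1C(=O)Nc1ccc(Cl)c(Cl)c1`: in a functional assay on HL-60 cells (Homo sapiens), with a stated time of 2 days (a lower number here means a stronger inhibitor, a higher number a weaker inhibitor), compound 1 gives 33100 nM
compound 2 `C[C@@H](NC(=O)c1[nH]cnc1C(=O)Nc1ccc(Cl)c(Cl)c1)c1ccccc1`: in this assay compound 2 gives 8800 nM
compound 3 `COC(=O)[C@@H](NC(=O)c1[nH]cnc1C(=O)Nc1ccc(Cl)c(Cl)c1)c1ccccc1`: in this assay compound 3 gives 13200 nM

Compound 2 holds the lowest number of the three; compound 3 lies within the scatter of it, compound 1 beyond it. Compound 4 `COC(=O)[C@H](NC(=O)c1[nH]cnc1C(=O)Nc1ccc(Cl)c(Cl)c1)C(C)C` differs from compound 2 by 1-(methoxycarbonyl)-2-methylpropyl in place of 1-phenylethyl on an amide-type nitrogen. For the measured compounds named here, only one measured step touches this change: a 1.5-fold higher number from compound 2 to compound 3 (0.18 log units; within the scatter), covering the methoxycarbonyl that enters. Going by the values given here, no measured step covers the exchange of the aromatic ring for a branched chain; the nearest hint is compound 1, which carries no aromatic ring at this nitrogen and gives 33100 nM, while compound 2 gives 8800 nM. A higher number is therefore expected for compound 4, a 2.3-fold higher number from compound 2 to compound 4 (0.36 log units; beyond the scatter). The estimate for compound 4 in this assay is 20000 nM, within 7000 nM to 55000 nM.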

Compound 4, half-maximal inhibitory concentration: 8500 nM
The estimate for compound 4 lay 2.4-fold (0.37 log units) above the measured number; low and high end bracket the measured number.
By their numbers in this assay, from the lowest: compounds 4, 2 and 3 (each within the scatter of the next); then compound 1.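

In this assay, an aromatic ring at this amide-type nitrogen is not needed to hold the level of compound 2: a 1.0-fold lower number from compound 2 to compound 4 (0.02 log units; within the scatter), with 1-(methoxycarbonyl)-2-methylpropyl carrying no ring. Compound 1, also without an aromatic ring here, gives 33100 nM, whereas compound 4 gives 8500 nM, so the lack of that ring alone does not go with the higher number. Nothing at hand gives a reason for this result.

As far as these compounds go, it remains open how a carboxylic acid in place of the methoxycarbonyl of compound 4 would read. From the compounds shown here alone, a simple 2-methylpropyl group without the ester is equally open.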